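The source may report more compounds than this note shows. Statements on the series, on what has been measured and on what is new or still open speak of the compounds shown alone.

Measured compounds:
Compound 1, `CN1CCC(NC(=O)c2cc(-c3ccc(NS(=O)(=O)c4cccc(Cl)c4Cl)cc3)nc3[nH]ncc23)C1`; in an assay for inhibition of serine/threonine-protein kinase Sgk1 (Homo sapiens), with stated times of 30 min and 60 min, in the presence of a further agent that is not named here (a higher number here means a weaker inhibitor, a lower number a stronger inhibitor), compound 1 gives < 1 nM.
Compound 2, `NCCNC(=O)c1cc(-c2ccc(NS(=O)(=O)c3cccc(Cl)c3Cl)cc2)nc2[nH]ncc12`; in this assay compound 2 gives < 1 nM.

Compound 1 stands at a limit of the assay rather than at a number; this is the limit of < 1 nM in this assay, at which 2 of the 2 values shown sit, so its true potency is not pinned down. Going by the values given here, the only step measured, a step that the two limits leave unreadable from compound 1 to compound 2, runs between two such limits and cannot be read.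

Compound 3, `CN1CCC(CNC(=O)c2cc(-c3ccc(NS(=O)(=O)c4cccc(Cl)c4Cl)cc3)nc3[nH]ncc23)C1`, differs from compound 1 in one place: (1-methylpyrrolidin-3-yl)methyl in place of 1-methylpyrrolidin-3-yl on an amide-type nitrogen. Among the compounds with values here, no measured step covers this change, and the one step that exists gives no size to lean on.

With both measured values sitting at the same limit, compound 3 is expected to stay close to it, a step of an at least 1.2-fold higher number from compound 1 to compound 3 (0.07 log units; that floor lies within the scatter). Compound 3 is estimated at 1.2 nM, with a range from 0.3 nM to 5 nM.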

Compound 3, half-maximal inhibitory concentration: 14 nM
Estimate against measurement, compound 3: 12-fold (1.07 log units) below, outside the stated range (above it).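

The change to (1-methylpyrrolidin-3-yl)methyl on the amide-type nitrogen gives an at least 14-fold higher number from compound 1 to compound 3 (1.14 log units; beyond the scatter), so in this assay the group at this place clearly matters, which the first two compounds could not show. Putting 1-methylpyrrolidin-3-yl in place of aminomethyl on the saturated chain carbon bound to that nitrogen gives an at least 14-fold higher number from compound 2 to compound 3 (1.14 log units; beyond the scatter), a second large step ending at the same compound. Both sizes are only floors, since each step starts from a value that is a limit and not a number: the limit of < 1 nM in this assay, at which 2 of the 3 values shown sit.

How far compound 1 and compound 2 truly lie from each other stays unreadable, as does the full size of either step. Going by these compounds, whether 3-aminopropyl, a longer chain ending in an amine, would keep the value at the limit on this nitrogen or move it away remains open.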